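The compounds below may be only part of what the source reports. "The series", "measured", "known", "first", "only" and "open" are said of these compounds alone.

Values in an ADME assay on Raji cells (Homo sapiens) for cytotoxicity, with a stated time of 72 h (a lower number here means that less compound is needed, a higher number that more compound is needed for the effect), so far:

- compound 1 `O=C(Nc1ccc(F)c(-c2nc3ccccc3o2)c1)c1cc([N+](=O)[O-])ccc1Cl`: > 25000 nM
- compound 2 `O=C(Nc1ccc(F)c(-c2nc3ccccc3s2)c1)c1cc([N+](=O)[O-])ccc1Cl`: > 25000 nM
- compound 3 `O=C(Nc1nc2ccc(F)cc2s1)c1cc([N+](=O)[O-])ccc1Cl`: > 27000 nM

All three entries are limits, not numbers, so the series cannot yet be ranked. Compound 1 stands at the limit of > 25000 nM in this assay, at which 2 of the 3 values shown sit, a position it shares with compound 2. Compound 3 stands at the limit of > 27000 nM in this assay, at which 1 of the 3 values shown sits.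

Next in view is compound 4 `O=C(Nc1cccc(-c2nc3ccccc3o2)c1)c1cc([N+](=O)[O-])ccc1Cl`, which has hydrogen in place of fluoro on an aromatic carbon of the core of compound 1: hydrogen in place of fluoro on an aromatic carbon. Among the compounds with values here, the only measured step, a step that the two limits leave unreadable from compound 1 to compound 2, changes a different group and gives no readable size. Within the data shown here, no measured step involves the loss of fluoro, so the size of this change has no direct measure.

The expectation therefore rests on the limits alone. Compound 1 supports it with > 25000 nM, a limit. No step beyond the scatter is expected in this assay, in either direction, and a further limit is the likeliest report. The expected step is a number no higher from compound 1 to compound 4 (the limit leaves the size open). For compound 4 the estimate is 25000 nM, with an expected range from 12000 nM to 50000 nM.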

Compound 4, half-maximal effective concentration in the Raji assay: > 25000 nM
Compound 4: only a limit was reported; the forecaster's own chance of this, stated with the estimate: 80%; the middle value sits exactly at the limit.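

In the Raji assay compound 4 gives > 25000 nM, which is a limit. In the Raji assay compound 1 gives > 25000 nM, which is also a limit. Within the data shown here, no step between these two compounds can be read. The compounds shown leave open whether any change to the shared core would give a number rather than a limit in the Raji assay. In a physicochemical assay for solubility, read by spectrophotometry, in phosphate buffer, measured as kinetic solubility, with a stated time of 18 h, at pH 7.4 (on this read-out lower numbers stand for lower solubility and higher numbers for higher solubility), compound 1 gives 270 nM, and compound 4 gives 470 nM. In the physicochemical assay the change of hydrogen in place of fluoro is a 1.7-fold higher number from compound 1 to compound 4 (0.24 log units; within the scatter).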